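This account rests on a few compounds, and the source may have more. Where it says the series, first, only, none or still open, it means among the compounds named here.

This piece follows a single change within a small set of compounds that share one core. In a physicochemical assay for solubility, read by HPLC, using the shake flask method, measured as kinetic solubility, with a stated time of 20 h, at pH 6.5, tested at 200 uM (on this read-out higher numbers stand for higher solubility and lower numbers for lower solubility), compound 1 `O=S(=O)(c1cccc(-c2ccc3nccc(-c4ccncc4)c3n2)c1)N1CCC(O)CC1` gives 10000 nM. Compound 2 `O=S(=O)(c1cccc(Nc2ccc3nccc(-c4ccncc4)c3n2)c1)N1CCCC1` returns only a limit of the assay in this assay, namely < 5000 nM. Compound 3 `NS(=O)(=O)c1cccc(-c2ccc3nccc(-c4ccncc4F)c3n2)c1` also returns only a limit in this assay, namely < 5000 nM. Compound 3 therefore stands at the limit of < 5000 nM in this assay, at which 2 of the 3 values shown sit, and compound 1 alone carries a full number. For the measured compounds named here, no step between two measured compounds has been computed, so no measured step is available to lean on.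

Compound 4 `CN1CCN(c2ccnc3ccc(-c4cccc(S(N)(=O)=O)c4)nc23)CC1` differs from compound 3 in one place: 4-methylpiperazin-1-yl in place of 3-fluoropyridin-4-yl on an aromatic carbon. With compound 3 at a limit, any step can only point upward or stay within the scatter. An upward step is expected here, estimated as an at least 8.0-fold higher number from compound 3 to compound 4 (0.90 log units; beyond the scatter), well beyond the usual scatter. For compound 4 the expected solubility in this assay is 40000 nM, with a range from 5000 nM to 200000 nM.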

Compound 4, solubility: 200000 nM
The estimate for compound 4 lay 5.0-fold (0.70 log units) below the measured number, within the range that was stated.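

At this position, on an aromatic carbon opposite the ring nitrogen, 4-methylpiperazin-1-yl in place of 3-fluoropyridin-4-yl gives an at least 40-fold higher number from compound 3 to compound 4 (1.60 log units; beyond the scatter) in this assay. For the compounds shown here, this is the first measured step in the set, and it shows that the group at this one place can move the read-out well beyond the scatter, even though both groups count 7 heavy atoms. The lower end of the step is a limit and not a number, so its true size stays unknown: the limit of < 5000 nM in this assay, at which 2 of the 4 values shown sit.

The compounds shown leave open whether the step goes with the non-aromatic ring or with the nitrogen count of the entering group. A morpholine or a piperidine at the same position would help separate those two readings.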